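Trimethoxyphenyl pyrazole chalcones: cytotoxicity on U-251 cells

A few compounds are considered here, and "the series" means these few. Any claim that something is new, unique, unknown or untested is made for them only; others in the source may bear on it.

Measured so far:
compound 1 `COc1cc(-c2cc(/C=C/C(=O)c3ccc(N)cc3)[nH]n2)cc(OC)c1OC` gives 94% in a functional assay on U-251 cells (Homo sapiens) for cytotoxicity, read by sulforhodamine B assay, with a stated time of 48 h, tested at 0.1 uM; a lower number here means a stronger effect, a higher number a weaker effect of the compound at the concentration tested
compound 2 `COc1cc(-c2cc(/C=C/C(=O)c3ccc(Cl)c(Cl)c3)[nH]n2)cc(OC)c1OC` gives 95% in this assay
compound 3 `COc1ccc(C(=O)/C=C/c2cc(-c3cc(OC)c(OC)c(OC)c3)n[nH]2)cc1OC` gives 95% in this assay

All three read-outs sit close to full signal, so none of the compounds shows much effect at this concentration. Compound 3 stands level with compound 2 at the digits printed, the two together being the highest of the three numbers; the step of no change at the digits printed from compound 2 to compound 3 (within the scatter) and the step of a number 1 percentage points higher from compound 1 to compound 3 (within the scatter) are both within the scatter.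

Compound 4 `COc1ccc(C(=O)/C=C/c2cc(-c3cc(OC)c(OC)c(OC)c3)n[nH]2)cc1` differs from compound 3 in one place: hydrogen in place of methoxy on an aromatic carbon. The steps measured so far all vary the aryl group on the carbonyl carbon, as does this change, and each of them (a number 1 percentage points higher from compound 1 to compound 2 (within the scatter), a number 1 percentage points higher from compound 1 to compound 3 (within the scatter), no change at the digits printed from compound 2 to compound 3 (within the scatter)) stayed within the scatter. For the measured compounds named here, no measured pair swaps a methoxy for hydrogen, so the expectation rests only on the flatness seen across these three. Compound 4 is therefore expected to show a step of a number 1 percentage points lower from compound 3 to compound 4 (within the scatter), nothing beyond the scatter. The estimate for compound 4 in this assay is 94%, with a range from 86% to 100%.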

Compound 4, a percentage reported as activity, at one concentration (the size of the read-out at that concentration, not a potency): 97%
For compound 4 the middle estimate is 3 percentage points below the measured one; measured number inside the range.
By their numbers in this assay, from the lowest: compounds 1, 2, 3 and 4 (each within the scatter of the next).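

Swapping methoxy for hydrogen on an aromatic carbon ortho to a methoxy group, which turns 3,4-dimethoxyphenyl into 4-methoxyphenyl, is the first change of this kind in the series, and in this assay it gives a number 2 percentage points higher from compound 3 to compound 4 (within the scatter) with no effect beyond the scatter. The 4-methoxyphenyl group also stays flat against the two other aryl groups on the carbonyl carbon, with a number 2 percentage points higher from compound 2 to compound 4 (within the scatter) and a number 3 percentage points higher from compound 1 to compound 4 (within the scatter) as the remaining steps, so the flatness now extends to a compound with one methoxy on this ring. Nothing available explains this flatness.

As far as these compounds go, all four compounds were read at one low concentration, so any differences that would appear at higher concentrations stay unknown. From the compounds shown here alone, it also remains open whether a carboxylic acid or a dimethylamino group on this ring would move the read-out beyond the scatter.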